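Bromo in place of hydrogen: compound 2 to compound 4

This account rests on a few compounds, and the source may have more. Where it says the series, first, only, none or still open, it means among the compounds named here.

Measured in an ADME assay on A2780 cells (Homo sapiens) for cytotoxicity, read by MTT assay, with a stated time of 72 h; on this read-out higher numbers stand for weaker inhibition of growth and lower numbers for stronger inhibition of growth:
compound 1 `CCCCNC(=O)C1C(C(=O)O)[C@@H]2CC[C@H]1O2`: 10000 nM
compound 2 `O=C(O)C1C(C(=O)Nc2ccccc2)[C@H]2CC[C@@H]1O2`: 10000 nM
compound 3 `O=C(O)CCCNC(=O)C1C(C(=O)O)[C@@H]2CC[C@H]1O2`: 10000 nM

Compound 1 and compound 3 stand level with compound 2 at 10000 nM. Compound 4 `O=C(O)C1C(C(=O)Nc2ccc(Br)cc2)[C@H]2CC[C@@H]1O2` is not yet measured and differs from compound 2 by one change: bromo in place of hydrogen on an aromatic carbon.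

Going by the values given here, three measured steps bear on this only indirectly. Changing the group on the amide nitrogen gives no change at the digits printed from compound 1 to compound 2 (within the scatter) and no change at the digits printed from compound 2 to compound 3 (within the scatter), while the change at the chain end gives no change at the digits printed from compound 1 to compound 3 (within the scatter). All three are null, so the series has shown no step of any size in this assay. Among the compounds with values here, none of them, however, places a substituent on the phenyl ring, and the data hold no direct precedent for bromo there.

The step of a 1.3-fold lower number from compound 2 to compound 4 (0.10 log units; within the scatter) is therefore expected to stay within the scatter, with some uncertainty towards stronger inhibition of growth. For compound 4 the estimated value is 8000 nM, with an expected range of 3000 nM to 15000 nM.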

Compound 4, concentration for 50% growth inhibition: 10000 nM
The estimate for compound 4 lay 1.3-fold (0.10 log units) below the measured number; the measured number falls inside the stated range.
By their numbers in this assay, from the lowest: compounds 1, 2, 3 and 4 (each within the scatter of the next).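

In this assay, going by these compounds alone, bromo on an aromatic carbon para to a large group gives no change at the digits printed from compound 2 to compound 4 (within the scatter) and is the first change made on the phenyl ring itself. The earlier steps shown here altered only the group on the amide nitrogen or the end of the chain, so the absence of any step beyond the scatter now also covers this one ring position. No evidence is available that bears on this result.

From the compounds shown here alone, whether any other group at this position would give a step remains open, for example an amine or a carboxylic acid on the same ring carbon. The compounds shown also leave open whether a change to the shared core, such as a methyl ester in place of the free carboxylic acid, would shift the number at all.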